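Moving the Fluorine on the Benzyloxy Group

This account rests on a few compounds, and the source may have more. Where it says the series, first, only, none or still open, it means among the compounds named here.

This account concerns a small set of compounds sharing one core and tested in a functional assay on HEK293 cells for agonist activity at G-protein coupled receptor 39 (Homo sapiens), read by scintillation proximity assay and inositol phosphate accumulation, with a stated time of 75 min, in the presence of a further agent that is not named here; a lower number here means that less compound is needed, a higher number that more compound is needed for the effect. Compound 1 `Cc1nn(-c2ncnc3nc[nH]c23)c2c1C(c1ccc(OC(C)C)cc1)CC(=O)N2` carries a 4-isopropoxyphenyl group on a saturated ring carbon, and in this assay compound 1 gives 18 nM. Compound 2 `Cc1nn(-c2ncnc3nc[nH]c23)c2c1C(OCc1ccccc1Cl)CC(=O)N2` carries a (2-chlorobenzyl)oxy group in its place, and compound 2 gives 2 nM, which amounts to a 9.0-fold lower number from compound 1 to compound 2 (0.95 log units; beyond the scatter). Compound 3 `Cc1nn(-c2ncnc3nc[nH]c23)c2c1C(OCc1ccccc1F)CC(=O)N2` carries a (2-fluorobenzyl)oxy group, and compound 3 gives 4 nM; that is a 4.5-fold lower number from compound 1 to compound 3 (0.65 log units; beyond the scatter), while the halogen exchange is a 2.0-fold higher number from compound 2 to compound 3 (0.30 log units; within the scatter). Among the three numbers, compound 3 holds the second highest, with compound 2 nearest to it and compound 1 furthest away.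

Compound 4 `Cc1nn(-c2ncnc3nc[nH]c23)c2c1C(OCc1ccc(F)cc1)CC(=O)N2` has not yet been measured. It differs from compound 3 in one respect only: 4-fluorophenyl in place of 2-fluorophenyl on a saturated chain carbon bound to an oxygen on a saturated carbon. For the measured compounds named here, no measured step compares a 2-fluorophenyl with a 4-fluorophenyl group, so the nearest guide is the halogen exchange, which stayed within the scatter, together with the observation that both benzyloxy compounds sat below compound 1 by a modest margin. The change is therefore expected to be small, a 1.5-fold higher number from compound 3 to compound 4 (0.18 log units; within the scatter), with no clear direction. Compound 4 is estimated to give 6 nM, within a range from 2 nM to 18 nM.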

Compound 4, half-maximal effective concentration: 1 nM
Estimate against measurement, compound 4: 6.0-fold (0.78 log units) above; measured number outside the range, below it.
By their numbers in this assay, from the lowest: compounds 4, 2 and 3 (each within the scatter of the next, the first and the last beyond it); then compound 1.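

Moving the fluorine within the benzyloxy group, with the same atoms joined differently, gives a 4.0-fold lower number from compound 3 to compound 4 (0.60 log units; beyond the scatter) in this assay and so shows that at this position the place of the halogen on the aromatic ring can change the number beyond the scatter, which the earlier exchange of chloro for fluoro did not show. The 4-fluorophenyl and 2-chlorophenyl groups cannot be separated here, since a 2.0-fold lower number from compound 2 to compound 4 (0.30 log units; within the scatter) stays within the scatter, so a change of halogen together with a change of its place leaves the number no clearly different, while the change of place alone in compound 3 and compound 4 does not. For the compounds shown here, replacing the 4-isopropoxyphenyl group on the saturated ring carbon with the (4-fluorobenzyl)oxy group gives an 18-fold lower number from compound 1 to compound 4 (1.26 log units; beyond the scatter) and is the only step in this set printed as large, widening the margin that the two earlier benzyloxy compounds had opened.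

The compounds shown leave open whether a nitrile, a methoxy group or a carboxylic acid in place of the fluorine would hold the number as low as the 4-fluorophenyl group does, and whether a longer chain in place of the benzyl carbon would do so. Nothing available here gives a reason for the effect of moving the fluorine.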